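Trading pyridin-3-yl for methyl on a shared core

The source may report more compounds than this note shows. Statements on the series, on what has been measured and on what is new or still open speak of the compounds shown alone.

Of the compounds shown here, three built on one shared core have been measured in a functional assay on KG-1 cells (Homo sapiens) for cytotoxicity, read by luminescence and CellTiter-Glo, with a stated time of 3 days; a lower number here means a stronger inhibitor, a higher number a weaker inhibitor. Compound 1 `N#Cc1ccc(NC(=O)c2cc(F)ccc2O)cc1` gives 2670 nM, compound 2 `O=C(Nc1ccc(OC(F)(F)F)cc1)c1cc(F)ccc1O` gives 780 nM, and compound 3 `N#Cc1ccc(NC(=O)c2cc(-c3cccnc3)ccc2O)cc1` gives 8330 nM. Compound 3 therefore has the highest number of the three and is the weakest inhibitor of this small set. Compound 1 is its nearest neighbour, and compound 2 lies furthest away.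

Compound 4 `Cc1ccc(O)c(C(=O)Nc2ccc(C#N)cc2)c1` has not yet been measured. It has methyl in place of pyridin-3-yl on an aromatic carbon, para to a hydroxy group: methyl in place of pyridin-3-yl on an aromatic carbon.

The measured step that bears most directly on this change sits at the same carbon: pyridin-3-yl in place of fluoro gave a 3.1-fold higher number from compound 1 to compound 3 (0.49 log units; beyond the scatter). Among the measured compounds shown here, removing pyridin-3-yl may largely reverse that modest step, although no methyl compound has been measured to confirm it. The other step, trifluoromethoxy in place of cyano, gave a 3.4-fold lower number from compound 1 to compound 2 (0.53 log units; beyond the scatter), but it concerns a group that compound 4 leaves as cyano, so it offers little guidance here.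

A modest drop in this assay is therefore expected, and the estimated step is a 2.8-fold lower number from compound 3 to compound 4 (0.44 log units; beyond the scatter). Compound 4 is estimated at 3000 nM, with an expected range from 1200 nM to 7500 nM.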

Compound 4, half-maximal inhibitory concentration: 3370 nM
Beside the measured number, compound 4's estimate is 1.1-fold (0.05 log units) below it; measured number inside the range.
By their numbers in this assay, from the lowest: compound 2; then compounds 1 and 4 (each within the scatter of the next); then compound 3.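

In this assay, methyl in place of pyridin-3-yl gives a 2.5-fold lower number from compound 3 to compound 4 (0.39 log units; beyond the scatter), so the higher number of compound 3 goes with the pyridin-3-yl ring on this carbon and is lost when a single methyl carbon takes its place. Methyl in place of fluoro gives a 1.3-fold higher number from compound 1 to compound 4 (0.10 log units; within the scatter), which puts these two groups within the scatter of each other, and of the three groups seen at this carbon, only pyridin-3-yl moves the number beyond the scatter. Nothing available here explains why the ring and the two other groups differ in this way.

Three groups at one carbon cannot show whether the higher number follows from any ring, from the ring nitrogen of pyridin-3-yl, or from the sheer count of atoms, and a phenyl ring or a longer chain such as propyl, or an amine, would help to separate these readings. On these data alone, it also remains open whether methyl and fluoro would still sit within the scatter of each other on the trifluoromethoxy side of the series, where compound 2 carries fluoro.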